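This account rests on a few compounds, and the source may have more. Where it says the series, first, only, none or still open, it means among the compounds named here.

Of the compounds shown here, two sharing a core have so far been tested in an in vitro ADME assay on microsomes from liver (Mus musculus) for metabolic stability; a lower number here means that the compound disappears faster, a higher number that the compound lasts longer. Compound 1 (`CN1CCN(C(=O)c2cc3cc(Cl)cc(N)c3[nH]2)CC1`) gives 0.233 h, and compound 2 (`CNC1CN(C(=O)c2cc3cc(Cl)cc(C)c3[nH]2)C1`) gives 0.433 h. These two values lie within the usual scatter of each other, so the numbers do not separate compound 2 from compound 1.

Compound 3 (`Cc1cc(Cl)cc2cc(C(=O)N3CC(N4CCCC4)C3)[nH]c12`) keeps the rest of compound 2 but carries pyrrolidin-1-yl in place of methylamino on a saturated ring carbon. Within the data shown here, no two measured compounds differ by this change alone, so the data offer no direct guide to its effect. A step beyond the scatter is therefore not expected in this assay, in either direction. The expected step, a 1.2-fold lower number from compound 2 to compound 3 (0.09 log units; within the scatter), is estimated to stay small. Compound 3 is expected to show a half-life of 0.35 h, with an estimated range from 0.15 h to 0.8 h.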

Compound 3, half-life in the liver assay: 0.183 h
Beside the measured number, compound 3's estimate is 1.9-fold (0.28 log units) above it; the measured number falls inside the stated range.
By their numbers in the liver assay, from the lowest: compounds 3, 1 and 2 (each within the scatter of the next, the first and the last beyond it).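

In the liver assay, pyrrolidin-1-yl in place of methylamino on a saturated ring carbon of the four-membered ring gives a 2.4-fold lower number from compound 2 to compound 3 (0.37 log units; beyond the scatter). Among these compounds, this is the first step in these compounds that can be read beyond the scatter, and it shows that the half-life can move with the group carried at this position. The same change also comes with a lower number in a physicochemical assay for solubility, at pH 6.8; on this read-out lower numbers stand for lower solubility and higher numbers for higher solubility: the measured solubility of compound 2, 51 ug/mL, and of compound 3, 10 ug/mL, a 5.1-fold lower number (0.71 log units; beyond the scatter) Thus, in the physicochemical assay, compound 2 gives 51 ug/mL and compound 3 gives 10 ug/mL.

This single step cannot separate the loss of the hydrogen-bond donor from the gain of the five-membered ring. From the compounds shown here alone, it remains open whether dimethylamino on the same carbon, which has no such donor and no ring, would stand nearer compound 2 or compound 3 in the liver assay and in the physicochemical assay.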